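The compounds below may be only part of what the source reports. "The series", "measured", "known", "first", "only" and "open" are said of these compounds alone.

In a functional assay on the whole organism (aorta) with Rattus norvegicus as the target (a lower number here means a smaller maximal response, a higher number a larger maximal response), three compounds have been measured:

compound 1, `C/N=C(/S)C1=CC(C)(C)Oc2ccc([N+](=O)[O-])cc21`, gives 63.5%
compound 2, `C/N=C(/S)C1=CC(C)(C(F)(F)F)Oc2ccc([N+](=O)[O-])cc21`, gives 62.5%
compound 3, `CC1(C(F)(F)F)C=C(/C(S)=N\CCC#N)c2cc([N+](=O)[O-])ccc2O1`, gives 69.7%

Compound 4, `N#CCC/N=C(/S)C1=CC(C(F)(F)F)(C(F)(F)F)Oc2ccc([N+](=O)[O-])cc21`, has not yet been measured in this assay. The change leading from compound 3 to compound 4 is trifluoromethyl in place of methyl on a saturated ring carbon. The same kind of change separates compound 1 from compound 2, (trifluoromethyl in place of methyl on a saturated ring carbon), where the place lies two ring bonds from the ring atom that bears a group of 4 heavy atoms, whereas in compound 3 that ring atom bears a group of 7 heavy atoms. That earlier step gave a number 1 percentage points lower from compound 1 to compound 2 (within the scatter). The difference between the core of compound 1 and the core of compound 3 is not broken down here; the change from compound 2 onward gave a number 7.2 percentage points higher from compound 2 to compound 3 (within the scatter). Because a number 1 percentage points lower from compound 1 to compound 2 (within the scatter) stayed within the scatter, the step in this assay is expected to be small as well, a number 1.2 percentage points lower from compound 3 to compound 4 (within the scatter). Compound 4 is therefore estimated at 68.5%, expected to lie between 58% and 79%.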

Compound 4, intrinsic activity: the largest response reached, in percent of the reference agonist's: 74.8%
For compound 4 the middle estimate is 6.3 percentage points below the measured one; the measured number falls inside the stated range.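

In this assay, trifluoromethyl in place of methyl on a saturated ring carbon gave a number 5.1 percentage points higher from compound 3 to compound 4 (within the scatter). Set beside the earlier step, the change shows no difference between the two cores that can be told apart: the same change on two cores in this assay, a number 1 percentage points lower (within the scatter) from compound 1 to compound 2 and a number 5.1 percentage points higher (within the scatter) from compound 3 to compound 4, 6.1 percentage points apart, within the scatter of two such steps. Within the data shown here, this shows only that the step stayed within the scatter on both cores; two such small steps do not establish a fixed size or direction for the change, nor that it would behave alike on any further core.

The compounds shown leave open what an ethyl group or a phenyl ring would do on that saturated ring carbon. Also open, from the compounds shown here alone, is the effect of a carboxylic acid or an amine at the end of the chain on the double-bonded nitrogen.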